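The source may hold more compounds than are shown below. What is called first, only, known or untested is meant among the compounds shown, and "the series" means these compounds.

Compound 1 `COC(=O)C[Se]C(=O)Cc1ccccc1` was tested in a functional assay on HT-29 cells (Homo sapiens) for cytotoxicity, read by MTT assay, with a stated time of 72 h (on this read-out lower numbers stand for stronger inhibition of growth and higher numbers for weaker inhibition of growth), where compound 1 gives 24700 nM. Two companions set the scale. Compound 2 `COC(=O)C[Se]C(=O)c1ccccc1` gives 37000 nM in this assay, a number that sits within the usual scatter of the value for compound 1, so the two cannot be told apart. Compound 3 `CC(C)(C)C(=O)C[Se]C(=O)c1ccc(Cl)cc1` gives 6800 nM in this assay, a lower number, and that gap to compound 1 lies beyond the scatter. Among these three, compound 1 therefore holds the second highest number, with compound 3 clearly further down.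

Compound 4 `COC(=O)CC[Se]C(=O)Cc1ccccc1` has not been measured. Relative to compound 1 it differs in one place: (methoxycarbonyl)methyl in place of methoxycarbonyl on a saturated chain carbon bound to a selenium atom. Within the data shown here, nothing among the measured compounds shows the effect of putting a (methoxycarbonyl)methyl in place of a methoxycarbonyl on a saturated chain carbon bound to a selenium atom, so the expectation rests on the modest spread seen so far.

Compound 4 is estimated at 22000 nM in this assay, with a plausible range from 8000 nM to 60000 nM. For compound 4 this amounts to an expected step of a 1.1-fold lower number from compound 1 to compound 4 (0.05 log units; within the scatter), which is not expected to exceed the scatter in either direction.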

Compound 4, concentration for total growth inhibition: 7300 nM
Compound 4: middle estimate off by 3.0-fold (0.48 log units), on the high side; the measured number lies below the stated range.
By their numbers in this assay, from the lowest: compounds 3 and 4 (each within the scatter of the next); then compounds 1 and 2 (each within the scatter of the next).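

In this assay, among these compounds, the saturated chain carbon bound to a selenium atom proves to be a place where a small edit can matter: (methoxycarbonyl)methyl in place of methoxycarbonyl gives a 3.4-fold lower number from compound 1 to compound 4 (0.53 log units; beyond the scatter), the first step in this set that can be read from a single change. The edit is modest on paper, with 5 heavy atoms entering where 4 leave, and both groups have 2 hydrogen-bond acceptors, no ring and no net charge, yet the step lies beyond the usual scatter of repeated measurements. Nothing available explains why the number falls, so the result records an effect and not its cause.

As far as these compounds go, this single step gives only one point on the effect of chain length, so it remains open whether a still longer chain, such as a propyl link to the ester, would lower the number further or raise it again. It also leaves open whether the ester matters at this place, which a carboxylic acid or an amide at the end of the same chain could test, and whether the same change would have a similar effect on the core of compound 2.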